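This account rests on a few compounds, and the source may have more. Where it says the series, first, only, none or still open, it means among the compounds named here.

Measured so far, in an assay on U-937 cells for inhibition of Fatty-acid amide hydrolase 1 (Homo sapiens), read by scintillation counting, with a stated time of 15 min; on this read-out higher numbers stand for weaker inhibition and lower numbers for stronger inhibition:

compound 1, `COc1ccc(-c2cc(C(=O)NC3CCCCCC3)c(OCc3ccc(F)cc3)nc2C)cc1`, gives only a limit, > 10000 nM.
compound 2, `Cc1c(Cl)cc(C(=O)NC2CCCCCC2)c(=O)n1Cc1ccc(F)cc1`, gives 5900 nM.
compound 3, `Cc1c(Br)cc(C(=O)NC2CCNCC2)c(=O)n1Cc1ccc(F)cc1`, gives only a limit, > 10000 nM.

Compound 2 holds the single numerical half-maximal inhibitory concentration in this set; the other two results are the limit of > 10000 nM in this assay, at which 2 of the 3 values shown sit. Among the compounds with values here, compound 2 itself is a weak inhibitor in this assay, and the set gives no measured step that isolates any single structural exchange.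

Compound 4, `Cc1c(-c2ccccc2)cc(C(=O)NC2CCCCCC2)c(=O)n1Cc1ccc(F)cc1`, differs from compound 2 by phenyl in place of chloro on an aromatic carbon. Within the data shown here, no measured pair shows what this exchange does here, so no direction follows from the data. The step from compound 2 to compound 4 is expected to be modest, a 1.7-fold lower number from compound 2 to compound 4 (0.23 log units; within the scatter), inside or near the scatter. Compound 4 is therefore estimated at 3500 nM, within 800 nM to 15000 nM.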

Compound 4, half-maximal inhibitory concentration: 560 nM
Compound 4: the middle estimate sits 6.3-fold (0.80 log units) above what was measured; the whole stated range lies above it.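

In this assay, within the data shown here, the aromatic carbon ortho to a methyl group proves sensitive to its substituent: phenyl in place of chloro gives an 11-fold lower number from compound 2 to compound 4 (1.02 log units; beyond the scatter) and is the first readable step. This single pair shows the size of the change, not its cause. Neither compound 1 nor compound 3 adds a number to compare: the limit of > 10000 nM in this assay, at which 2 of the 4 values shown sit.

Still open, going by these compounds, is whether the gain requires an aromatic ring at this carbon, which a cyclohexyl group or a longer alkyl chain would test. Also open, on these data alone, is whether a methoxy group or an amine on the new phenyl would add to it.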